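Swapping Trifluoromethyl for Methoxy in a Weak Amide

The compounds below may be only part of what the source reports. "The series", "measured", "known", "first", "only" and "open" are said of these compounds alone.

Two compounds have been run in a functional assay on NUGC-3 cells (Homo sapiens) for antiproliferative activity, read by sulforhodamine B assay; on this read-out lower numbers stand for stronger inhibition of growth and higher numbers for weaker inhibition of growth. Compound 1 `O=C(Nc1cccc([N+](=O)[O-])c1)Nc1nc2ccc(Cl)cc2s1` gives 1.03 ug/mL. Compound 2 `COc1cccc2sc(NC(=O)c3ccc(C(F)(F)F)cc3)nc12` returns only a limit, > 10 ug/mL. That limit is described by the limit of > 10 ug/mL in this assay, at which 1 of the 2 values shown sits. Compound 3 `COc1ccc(C(=O)Nc2nc3c(OC)cccc3s2)cc1` has not been measured; it differs from compound 2 by methoxy in place of trifluoromethyl on an aromatic carbon. Among the compounds with values here, no step between measured compounds offers a guide for this change, and the starting point is itself a limit rather than a number. With nothing to argue that the replacement moves growth inhibition beyond the usual scatter, compound 3 is expected to stay in the region of that limit, and more likely than not to return a limit again. For compound 3 the estimate in this assay is 12 ug/mL, with an expected range from 3 ug/mL to 40 ug/mL, which corresponds to an expected step that the limit leaves unreadable from compound 2 to compound 3.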

Compound 3, concentration for 50% growth inhibition: 3.46 ug/mL
For compound 3 the middle estimate is 3.5-fold (0.54 log units) above the measured one, within the range that was stated.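

In this assay, methoxy in place of trifluoromethyl on an aromatic carbon, para to a large group, gives an at least 2.8-fold lower number from compound 2 to compound 3 (0.46 log units; beyond the scatter), so growth inhibition in this pair does respond to the group at this position. The full size of the step cannot be read, because compound 2 gives only a limit and not a number: the limit of > 10 ug/mL in this assay, at which 1 of the 3 values shown sits. Of the two amides shown, only compound 3 gives a readable number, so it is the first firm reference point for changes at this position.

A single exchange cannot separate the loss of trifluoromethyl from the arrival of methoxy. Going by these compounds, it remains open how a plain hydrogen, an amine or a carboxylic acid at this position would compare with compound 3, and whether the same step would appear on another core.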